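The source may hold more compounds than are shown below. What is called first, only, known or untested is meant among the compounds shown, and "the series" means these compounds.

In an assay on cells for activation of Cystic fibrosis transmembrane conductance regulator (Homo sapiens), read by fluorescence, with stated times of 10 min and 12 s (on this read-out lower numbers stand for an effect already at smaller amounts and higher numbers for an effect only at larger amounts of compound), compound 1 `CCN(CC)c1nc(Nc2cccc([N+](=O)[O-])c2)nc(OC(C(F)(F)F)C(F)(F)F)n1` gives 200 nM, compound 2 `CCN(CC)c1nc(Nc2ccc(C(=O)O)cc2)nc(OC(C(F)(F)F)C(F)(F)F)n1` gives 900 nM, and compound 3 `CCN(CC)c1nc(Nc2ccc([N+](=O)[O-])cc2)nc(OC(C(F)(F)F)C(F)(F)F)n1` gives 18000 nM, the highest number of the three and beyond the scatter from both others, so compound 3 is the weakest of the set. Two measured steps alter the aryl group on the ring nitrogen, and both are large: a 90-fold higher number from compound 1 to compound 3 (1.95 log units; beyond the scatter) and a 20-fold higher number from compound 2 to compound 3 (1.30 log units; beyond the scatter). Compound 4 `CCN(CC)c1nc(Nc2ccc3ncsc3c2)nc(OC(C(F)(F)F)C(F)(F)F)n1` carries the change (1,3-benzothiazol-6-yl in place of 4-nitrophenyl on a nitrogen on an aromatic ring). Compound 3 sits at the weak end due to 18000 nM, and each other aryl group measured gave a lower number, so a downward step beyond the scatter is expected, a 12-fold lower number from compound 3 to compound 4 (1.08 log units; beyond the scatter). Compound 4 is estimated at 1500 nM, within 200 nM to 10000 nM.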

Compound 4, half-maximal effective concentration: 50 nM
Beside the measured number, compound 4's estimate is 30-fold (1.48 log units) above it; the measured number lies below the stated range.
By their numbers in this assay, from the lowest: compound 4; then compound 1; then compound 2; then compound 3.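

In this assay this place on the nitrogen accepts 1,3-benzothiazol-6-yl, which adds a five-membered aromatic ring and carries neither nitro nor carboxy, with a 360-fold lower number from compound 3 to compound 4 (2.56 log units; beyond the scatter) and an 18-fold lower number from compound 2 to compound 4 (1.26 log units; beyond the scatter) as its steps. The change also improves on the best substituted phenyl, with a 4.0-fold lower number from compound 1 to compound 4 (0.60 log units; beyond the scatter) as the smallest step, so compound 4 is the most potent of the four. On these data alone, what the sulfur-bearing ring contributes remains open, as does how an amine or a 3-carboxyphenyl group would read here. Nothing available explains these steps.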